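From butyl to propargyl on the shared core

A few compounds are considered here, and "the series" means these few. Any claim that something is new, unique, unknown or untested is made for them only; others in the source may bear on it.

Values so far in a functional assay (muscle tissue) with Rattus norvegicus as the target; a higher number here means that more compound is needed for the effect, a lower number that less compound is needed
- compound 1 `CNC(=O)C1=CC(C)(C)Oc2ccc(C#N)cc21` gives 263 nM
- compound 2 `CCCNC(=O)C1=CC(C)(C)Oc2ccc([N+](=O)[O-])cc21` gives 5.75 nM
- compound 3 `CCCCNC(=O)C1=CC(C)(C)Oc2ccc([N+](=O)[O-])cc21` gives 21.9 nM

Among these three numbers, compound 3 holds the middle place. Compound 2 lies below it and compound 1 above it, both beyond the usual scatter. Compound 1 also carries a nitrile and differs from compound 3 in more than one place, so it offers no clean comparison here.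

Compound 4 `C#CCNC(=O)C1=CC(C)(C)Oc2ccc([N+](=O)[O-])cc21` has not yet been measured. The change that leads to it is ethynyl in place of propyl on a saturated chain carbon bound to an amide-type nitrogen in the amide chain, so that butyl gives way to propargyl. In words, this is ethynyl in place of propyl on a saturated chain carbon bound to an amide-type nitrogen.

Among the compounds with values here, only one measured step bears on this change. It is a 3.8-fold higher number from compound 2 to compound 3 (0.58 log units; beyond the scatter) and is modest in size. Here the longer butyl chain goes with the higher number. Propargyl is a shorter chain than butyl, as is the propyl of compound 2, but no measured compound carries a triple bond in this chain, so the comparison is only partial.

The step expected in this assay is a 2.2-fold lower number from compound 3 to compound 4 (0.34 log units; beyond the scatter) and would thus be modest and towards a lower number. Compound 4 is estimated to read 10 nM (3 nM to 35 nM) when measured.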

Compound 4, half-maximal effective concentration: 7.94 nM
Beside the measured number, compound 4's estimate is 1.3-fold (0.10 log units) above it; measured number inside the range.
By their numbers in this assay, from the lowest: compounds 2 and 4 (each within the scatter of the next); then compound 3; then compound 1.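

In this assay, a triple bond in the amide chain turns out to be compatible with a low number: ethynyl in place of propyl on the saturated chain carbon bound to the amide-type nitrogen gives a 2.8-fold lower number from compound 3 to compound 4 (0.44 log units; beyond the scatter). The comparison with the propyl chain gives a 1.4-fold higher number from compound 2 to compound 4 (0.14 log units; within the scatter), so the propargyl and propyl chains cannot be told apart in this assay, while the butyl chain stands apart from both. Within the data shown here, until now, the only clean step at this position was a change in the length of a saturated chain, and this result adds a chain of a different kind, with no cost beyond the scatter relative to propyl, although nothing available accounts for these differences.

The compounds shown cannot separate any role of the triple bond from that of chain length, as a longer chain ending in a triple bond, such as butynyl, is absent from them. They also leave open how a chain carrying an amine or a carboxylic acid would read at this position, and whether the nitrile of compound 1 would keep these chain differences.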